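Swapping the phenyl of compound 3

The source may hold more compounds than are shown below. What is called first, only, known or untested is meant among the compounds shown, and "the series" means these compounds.

In a functional assay on CCRF-CEM cells (Homo sapiens) for inhibition (a higher number here means a weaker inhibitor, a lower number a stronger inhibitor), compound 1 `Cc1cccc(-c2cnc(Nc3ccc4c(C#N)cn(C)c4c3)o2)c1` reads > 10000 nM as a limit of the assay and not a number. Compound 2 `Cn1cc(C#N)c2ccc(Nc3ncc(-c4cccc(NC(=O)c5ccccc5)c4)o3)cc21` gives 3500 nM and compound 3 `Cn1cc(C#N)c2ccc(Nc3ncc(-c4cccc(CNC(=O)c5ccccc5)c4)o3)cc21` gives 5300 nM there, and a 1.5-fold higher number from compound 2 to compound 3 (0.18 log units; within the scatter) leaves compound 3 level with compound 2. Compound 4 `Cn1cc(C#N)c2ccc(Nc3ncc(-c4cccc(CNC(=O)OC5CCOC5)c4)o3)cc21` differs from compound 3 by (oxolan-3-yl)oxy in place of phenyl on a carbonyl carbon with (oxolan-3-yl)oxy in place of phenyl on a carbonyl carbon. Two measured steps bring that phenyl in: an at least 2.8-fold lower number from compound 1 to compound 2 (0.45 log units; beyond the scatter) is modest, and an at least 1.8-fold lower number from compound 1 to compound 3 (0.27 log units; that floor lies within the scatter) has its floor within the scatter. For the measured compounds named here, no measured step alters the phenyl itself. An estimated 1.3-fold lower number from compound 3 to compound 4 (0.12 log units; within the scatter) is therefore expected to stay within the scatter, with no firm direction. In this assay the estimate for compound 4 is 4000 nM within an expected range of 1000 nM to 10000 nM.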

Compound 4, half-maximal inhibitory concentration: > 10000 nM
Compound 4: only a limit was reported (the forecaster's own chance of this, stated with the estimate: 12%); middle value at least 2.5-fold (0.39 log units) from the limit.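

In this assay compound 4 gives > 10000 nM, which is a limit of the assay and not a number. The first change shown to the phenyl on this carbonyl carbon brings no sign of a gain: an at least 1.8-fold higher number from compound 3 to compound 4 (0.27 log units; that floor lies within the scatter), while an at least 2.8-fold higher number from compound 2 to compound 4 (0.45 log units; beyond the scatter). The step from compound 1 to compound 4 cannot be read: the limit of > 10000 nM in this assay, at which 2 of the 4 values shown sit.

Going by these compounds, how far compound 4 lies past its limit stays open. So does how an amine or a carboxylic acid in place of the phenyl would read in this assay.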